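A few compounds are considered here, and "the series" means these few. Any claim that something is new, unique, unknown or untested is made for them only; others in the source may bear on it.

Compound 1 `O=C(NCc1ccc(F)cc1)c1nc(Br)c2cccnc2c1NCc1ccc(F)cc1`: > 20000 nM
Compound 2 `CN(C)c1ccc(CNC(=O)c2nc(Br)c3cccnc3c2N[C@H]2CC[C@H](N)CC2)cc1`: "not determined" (no result reported)
Compound 3 `O=C(NCCCNc1c(C(=O)NCc2ccc(F)cc2)nc(Br)c2cccnc12)c1ccccc1`: > 10000 nM

In a functional assay on HCT-116 cells (Homo sapiens) for cytotoxicity, read by MTT assay, with a stated time of 72 h (a lower number here means a stronger inhibitor, a higher number a weaker inhibitor), compound 1 gives > 20000 nM, which is a limit of the assay and not a number. Compound 3 gives > 10000 nM, again a limit rather than a number. For compound 2 no result was reported. Compound 3 therefore stands at a limit, with one further compound also at a limit and one without any number at all. Among the compounds with values here, the single step between measured compounds, a step that the two limits leave unreadable from compound 1 to compound 3, cannot be read because of the limit of > 10000 nM in this assay, at which 1 of the 3 values shown sits, and (the limit of > 20000 nM in this assay, at which 1 of the 3 values shown sits).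

Compound 4 `NCCCCCCNc1c(C(=O)NCc2ccc(F)cc2)nc(Br)c2cccnc12` is the next compound in this series. The change from compound 3 is 3-aminopropyl in place of benzamido on a saturated chain carbon, three bonds along the chain from a nitrogen on an aromatic ring. Within the data shown here, no measured step bears on this change with a readable size, so no direction beyond the scatter can be taken from the data. For compound 4 the value in this assay is estimated at 15000 nM, within a range from 3000 nM to 60000 nM. This estimate means an expected step that the limit leaves unreadable from compound 3 to compound 4.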

Compound 4, half-maximal inhibitory concentration: 7000 nM
Compound 4: middle estimate off by 2.1-fold (0.33 log units), on the high side; the range from low to high includes it.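

Compound 4 gives 7000 nM in this assay, the first real number among these compounds, and it comes from a chain that ends in an amine. Placing 5-aminopentyl in place of 4-fluorophenyl on a saturated chain carbon bound to a nitrogen on an aromatic ring gives an at least 2.8-fold lower number from compound 1 to compound 4 (0.45 log units; beyond the scatter), while placing 3-aminopropyl in place of benzamido gives an at least 1.4-fold lower number from compound 3 to compound 4 (0.15 log units; that floor lies within the scatter). Compound 1 and compound 3 each stand at a limit, so both steps are floors and not full sizes.

As far as these compounds go, what remains open is whether the amine or the length of the chain matters more: a chain of the same length ending in a hydroxyl or a carboxylic acid, and a shorter chain ending in an amine, would separate the two. From the compounds shown here alone, the true distance between compound 3 and compound 4 also stays open.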